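Fluoro on the Fused Ring and Cytotoxicity of Compound 4

The compounds below may be only part of what the source reports. "The series", "measured", "known", "first", "only" and "open" are said of these compounds alone.

Of the compounds shown here, three have been measured in an ADME assay on MCF-10A cells (Homo sapiens) for cytotoxicity, read by MTT assay, with a stated time of 72 h; on this read-out higher numbers stand for weaker inhibition and lower numbers for stronger inhibition. Compound 1 `Cc1ccc(-c2ccc(F)cc2)n1-c1ccc(-c2nc3ccccc3s2)cc1` gives 40000 nM in this assay, compound 3 `Cc1ccc(-c2ccc(F)cc2)n1-c1ccc(-c2nc3ccc(F)cc3s2)cc1` gives 37800 nM, and compound 2 `COc1cc(-c2ccc(C)n2-c2ccc(-c3nc4ccccc4s3)cc2)cc(OC)c1OC` gives 38800 nM; all three values lie within the scatter of one another. Compound 3 arises from compound 1 by fluoro in place of hydrogen on an aromatic carbon, and this change gave a 1.1-fold lower number from compound 1 to compound 3 (0.02 log units; within the scatter). The difference between the core of compound 1 and the core of compound 2 is not broken down here. Compound 4 `COc1cc(-c2ccc(C)n2-c2ccc(-c3nc4ccc(F)cc4s3)cc2)cc(OC)c1OC`, not yet measured, arises from compound 2 by fluoro in place of hydrogen on an aromatic carbon, the same change as from compound 1 to compound 3, described at a place worded identically. The step that this expectation means, a 1.0-fold lower number from compound 2 to compound 4 (0.01 log units; within the scatter), is expected to stay within the scatter because the matching step was a 1.1-fold lower number from compound 1 to compound 3 (0.02 log units; within the scatter). Compound 4 is accordingly estimated at 38000 nM in this assay, between 20000 nM and 70000 nM.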

Compound 4, half-maximal inhibitory concentration: 40000 nM
The estimate for compound 4 lay 1.1-fold (0.02 log units) below the measured number; the measured number falls inside the stated range.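

In this assay, fluoro in place of hydrogen on an aromatic carbon gives a 1.0-fold higher number from compound 2 to compound 4 (0.01 log units; within the scatter). Set beside the earlier step, the change carries from one core to the other with no difference that can be told apart: the same change on two cores in this assay, a 1.1-fold lower number (0.02 log units; within the scatter) from compound 1 to compound 3 and a 1.0-fold higher number (0.01 log units; within the scatter) from compound 2 to compound 4, 1.1-fold (0.04 log units) apart, within the scatter of two such steps. For the compounds shown here, since neither step leaves the scatter, this shows only that the change made no discernible difference on either of these two cores; it does not show that a real effect would carry over, or that the same would hold on any other core.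

The compounds shown leave open whether a different group on the same aromatic carbon, such as chloro, methoxy or an amine, would move the number beyond the scatter.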